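Methoxy to Hydroxy on a Shared Core

A few compounds are considered here, and "the series" means these few. Any claim that something is new, unique, unknown or untested is made for them only; others in the source may bear on it.

Of the compounds shown here, three have been measured in a functional assay on OVCAR-8 cells (Homo sapiens) for inhibition, read by sulforhodamine B assay, with a stated time of 48 h; on this read-out higher numbers stand for weaker inhibition of growth and lower numbers for stronger inhibition of growth. Compound 1 `COc1cc(C)cc(-c2c(-c3ccnc(-c4ccc(N(C)C)cc4)c3)cnn2CC#N)c1` gives 236 nM, compound 2 `COc1cc(C)cc(-c2nn(CC#N)cc2-c2ccnc(-c3ccc(N(C)C)cc3)c2)c1` gives 522 nM, and compound 3 `COc1cc(C)cc(-c2nn(CC#N)cc2-c2ccc(-c3cccc(C(C)=O)c3)nc2)c1` gives 3160 nM. Compound 2 thus stands second highest of the three: compound 1 sits lower by an amount beyond the scatter, and compound 3 sits higher by a larger amount, also beyond the scatter. Compound 4 `Cc1cc(O)cc(-c2nn(CC#N)cc2-c2ccnc(-c3ccc(N(C)C)cc3)c2)c1` has not yet been measured in this assay. It differs from compound 2 by hydrogen in place of methyl on an oxygen on an aromatic ring, so that methoxy becomes hydroxy. For the measured compounds named here, no measured pair shows this change, so only a modest step is expected, a 1.4-fold higher number from compound 2 to compound 4 (0.16 log units; within the scatter), leaning toward weaker inhibition. Compound 4 is therefore expected to give 750 nM, within 280 nM to 2000 nM.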

Compound 4, concentration for 50% growth inhibition: 4200 nM
Compound 4: middle estimate off by 5.6-fold (0.75 log units), on the low side, outside the stated range (above it).
By their numbers in this assay, from the lowest: compound 1; then compound 2; then compounds 3 and 4 (each within the scatter of the next).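

In this assay the change from methoxy to hydroxy is no small edit: losing one methyl from the oxygen gives an 8.0-fold higher number from compound 2 to compound 4 (0.91 log units; beyond the scatter) and so much weaker inhibition of growth. For the compounds shown here, this shows that the group on this oxygen matters on the shared core, which the earlier compounds could not show, as no two of them differ only here. No measurement shown accounts for the size of this loss.

Open, as far as these compounds go, is how a longer chain such as ethoxy, or an amine or fluorine in the same place, would compare. Also open, from the compounds shown here alone, is whether this change would have the same effect on the core of compound 1.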